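This account rests on a few compounds, and the source may have more. Where it says the series, first, only, none or still open, it means among the compounds named here.

Measured compounds in a functional assay on MCF7 cells (Homo sapiens) for cytotoxicity, read by sulforhodamine B assay, with a stated time of 48 h; on this read-out lower numbers stand for stronger inhibition and higher numbers for weaker inhibition:
- compound 1, `CCCC[C@@H](/C=C\[C@@H]1OC(=O)C=C[C@@H]1OC(C)=O)OC(C)=O`: compound 1 gives 3200 nM
- compound 2, `CCCC[C@H](O)/C=C\[C@@H]1OC(=O)C=C[C@@H]1OC(C)=O`: compound 2 gives 9300 nM

Among the compounds with values here, compound 1 stands lowest of the two numbers so far; the nearest is compound 2, reached by a 2.9-fold higher number from compound 1 to compound 2 (0.46 log units; beyond the scatter), a modest step that still lies beyond the scatter.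

Compound 3, `CCCC[C@@H](/C=C\[C@@H]1OC(=O)C=C[C@@H]1O)OC(C)=O`, is not yet measured. Its difference from compound 1 is hydrogen in place of acetyl on an oxygen on a saturated carbon. Within the data shown here, the only measured step that bears on it is a 2.9-fold higher number from compound 1 to compound 2 (0.46 log units; beyond the scatter), the same kind of replacement of an acetyl by hydrogen on an oxygen on a saturated carbon, though at another of the two acetoxy groups. On that single precedent, a step of similar size and in the same direction, toward a higher number, is expected for compound 3, though a single step is a thin basis and a result within the scatter would not surprise. The estimated step is a 2.5-fold higher number from compound 1 to compound 3 (0.40 log units; beyond the scatter). Compound 3 is accordingly expected to give 8000 nM in this assay, within a range of 3500 nM to 18000 nM.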

Compound 3, half-maximal inhibitory concentration: 1000 nM
The estimate for compound 3 lay 8.0-fold (0.90 log units) above the measured number; measured number below the stated range.
By their numbers in this assay, from the lowest: compound 3; then compound 1; then compound 2.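

In this assay, acetoxy to hydroxy on the oxygen on a saturated carbon whose other neighbour is a saturated ring carbon lowers the number (a 3.2-fold lower number from compound 1 to compound 3 (0.51 log units; beyond the scatter)), so the acetyl at this position is not required for activity in the cells. The same kind of replacement at the other acetoxy group runs the opposite way (a 2.9-fold higher number from compound 1 to compound 2 (0.46 log units; beyond the scatter)), so the two acetoxy groups of compound 1 cannot be treated as interchangeable, and a step read at one does not carry over to the other. No evidence on hand accounts for this difference between the two positions.

Still open, as far as these compounds go, is how this oxygen responds to other substituents, such as a methyl ether, a benzoyl ester or an amine in place of the hydroxy. Also open, from the compounds shown here alone, is the outcome with hydrogen in place of both acetyl groups.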